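A few compounds are considered here, and "the series" means these few. Any claim that something is new, unique, unknown or untested is made for them only; others in the source may bear on it.

Measured compounds and their values:
Compound 1, `CC/C=C/C=C/[C@@]1(C)SC(O)=CC1=O`: > 80 ug/mL
Compound 2, `CCCC/C=C/C=C/[C@@]1(C)SC(O)=CC1=O`: 60 ug/mL
Compound 3, `CCCCCC[C@@]1(C)SC(O)=CC1=O`: > 80 ug/mL

In a functional assay on MCF7 cells (Homo sapiens) for inhibition, read by radiometric assay and XTT assay (on this read-out higher numbers stand for weaker inhibition and lower numbers for stronger inhibition), compound 1 gives > 80 ug/mL, which is a limit of the assay and not a number. In this assay compound 2 gives 60 ug/mL. The change between them is ethyl in place of hydrogen on a saturated chain carbon, two bonds along the chain from a double-bonded chain carbon, and it made a step of an at least 1.3-fold lower number from compound 1 to compound 2 (0.12 log units; that floor lies within the scatter). In this assay compound 3 gives > 80 ug/mL, again a limit of the assay rather than a number. How the core of compound 3 differs from the core of compound 1 is not broken down here. Compound 4, `CCCCCCCC[C@@]1(C)SC(O)=CC1=O`, is not yet measured. From compound 3 to compound 4 the change is ethyl in place of hydrogen on a saturated chain carbon, six bonds along the chain from a saturated ring carbon, the same kind of change as from compound 1 to compound 2, but not the same: here the place is six bonds along the chain from a saturated ring carbon, there two bonds along the chain from a double-bonded chain carbon. The expectation for this assay rests on the earlier step of an at least 1.3-fold lower number from compound 1 to compound 2 (0.12 log units; that floor lies within the scatter), which lies within the scatter, and on the limit at which compound 3 sits (the limit of > 80 ug/mL in this assay, at which 2 of the 3 values shown sit). The step from compound 3 to compound 4 is expected to be a number no higher from compound 3 to compound 4 (the limit leaves the size open). Compound 4 is therefore estimated to give about 80 ug/mL in this assay, and it may well again come out only as a limit.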

Compound 4, half-maximal inhibitory concentration: 17.6 ug/mL
Compound 4: middle estimate off by 4.5-fold (0.66 log units), on the high side; the measured number lies below the stated range.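

In this assay, the change on the core of compound 3 gives an at least 4.5-fold lower number from compound 3 to compound 4 (0.65 log units; beyond the scatter), so on this core it clearly lowers the number, which means stronger inhibition. Going by these compounds, compound 3 gives > 80 ug/mL, a limit of the assay and not a number, so the full size of this step stays unknown. Set beside the earlier step, the change does not raise the number on either core, but this does not show that it carries over with the same size, and the place also differs, six bonds along the chain from a saturated ring carbon in one case and two bonds along the chain from a double-bonded chain carbon in the other: the same change on two cores in this assay, an at least 1.3-fold lower number (0.12 log units; that floor lies within the scatter) from compound 1 to compound 2 and an at least 4.5-fold lower number (0.65 log units; beyond the scatter) from compound 3 to compound 4; the limit leaves it open whether they differ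

The compounds shown leave open whether a longer chain than the one in compound 4 would lower the number further or raise it again. They also leave open what an amine or a carboxylic acid would do in place of the ethyl.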